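This account rests on a few compounds, and the source may have more. Where it says the series, first, only, none or still open, it means among the compounds named here.

For the measured compounds named here, compound 1 `COCOc1cc(C2=C(c3cc(OC)c(OC)c(OC)c3)C(=O)CC2O[SiH2]C(C)(C)C)ccc1OC` gives the only number measured so far, 40 ug/mL in an ADME assay on ECV-304 cells (Homo sapiens) for cytotoxicity, read by MTT assay, with a stated time of 72 h; on this read-out lower numbers stand for stronger inhibition and higher numbers for weaker inhibition. Compound 2 `COc1cc(C2=C(c3cc(C)c(OC)c(C)c3)C(O)CC2=O)cc(OC)c1OC` reaches only the limit of this assay, > 100 ug/mL. Compound 3 `C=CCOc1cc(C2=C(c3cc(OC)c(OC)c(OC)c3)C(=O)C(O)C2)ccc1OC` likewise sits at the limit, > 100 ug/mL. Thus the limit of > 100 ug/mL in this assay, at which 2 of the 3 values shown sit, marks where two of the three values stand, and compound 1 alone supplies a number beneath it. Compound 4 `COc1ccc(C2=C(c3cc(OC)c(OC)c(OC)c3)C(=O)CC2O[SiH2]C(C)(C)C)cc1` differs from compound 1 by a single change: hydrogen in place of methoxymethoxy on an aromatic carbon. With no measured step between any two of these compounds, the size of this step in this assay is open; a modest move toward weaker inhibition, perhaps not beyond the usual scatter, is expected. Compound 4 is accordingly estimated at 60 ug/mL, within 20 ug/mL to 150 ug/mL, which means an expected step of a 1.5-fold higher number from compound 1 to compound 4 (0.18 log units; within the scatter).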

Compound 4, half-maximal inhibitory concentration: > 100 ug/mL
Compound 4 gave a limit, no number; the forecaster's own chance of this, stated with the estimate: 40%; middle value at least 1.6-fold (0.22 log units) from the limit.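

Hydrogen in place of methoxymethoxy, ortho to a methoxy group, is the first single change that can be read in this assay, and it brings an at least 2.5-fold higher number from compound 1 to compound 4 (0.39 log units; beyond the scatter). On these data alone, the value of compound 4 is a limit, so the full size of this step stays unknown. Among the compounds shown, compound 4 adds to those at that limit: the limit of > 100 ug/mL in this assay, at which 3 of the 4 values shown sit.

As far as these compounds go, what an amine or a carboxylic acid would do at this aromatic carbon stays open. From the compounds shown here alone, whether the same change would give a similar step on another core also stays open.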